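A few compounds are considered here, and "the series" means these few. Any claim that something is new, unique, unknown or untested is made for them only; others in the source may bear on it.

Measured compounds:
Compound 1, `CCOC(=O)c1cn2c(=O)n(C3CSC(CO)O3)ccc2n1`: in an ADME assay on HepG2 2.2.15 cells (Homo sapiens) for cytotoxicity, read by neutral red uptake (on this read-out higher numbers stand for lower toxicity in this test and lower numbers for higher toxicity in this test), compound 1 gives > 90000 nM, which is a limit of the assay and not a number.
Compound 2, `O=c1n(C2COC(CO)O2)ccc2nc(CO)cn12`: in this assay compound 2 gives 618000 nM.

Going by the values given here, compound 2 thus stands as the only outright number in this assay; the remaining value is a limit. Compound 1 supplies (the limit of > 90000 nM in this assay, at which 1 of the 2 values shown sits). Among the compounds with values here, no pair of measured compounds differs in a single place, so no measured step is available.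

Compound 3, `O=c1n(C2COC(CO)O2)ccc2nc(-c3ccc(F)cc3)cn12`, has not been measured. Compared with compound 2 the change is 4-fluorophenyl in place of hydroxymethyl on an aromatic carbon. Within the data shown here, with no measured step to lean on, the expectation for this assay is a moderate move toward higher toxicity, that is a lower number, of a size that may just exceed the usual scatter, though a flat outcome cannot be excluded. On that basis compound 3 is estimated at 200000 nM, within 50000 nM to 700000 nM, which as a step means an expected 3.1-fold lower number from compound 2 to compound 3 (0.49 log units; beyond the scatter).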

Compound 3, half-maximal cytotoxic concentration: 850000 nM
Compound 3: the middle estimate sits 4.3-fold (0.63 log units) below what was measured; measured number outside the range, above it.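

In this assay the exchange of hydroxymethyl for 4-fluorophenyl gives a 1.4-fold higher number from compound 2 to compound 3 (0.14 log units; within the scatter), so at this aromatic carbon the change leaves the read-out where it was. The position therefore accepts a larger group carrying a six-membered aromatic ring, while the hydrogen-bond donor and acceptor of hydroxymethyl are lost, with no measurable shift in this test. Nothing measured here accounts for this flat outcome.

On these data alone, whether an amine, a carboxylic acid or a longer alkyl chain at the same carbon would behave in the same way remains open. Compound 1 gives > 90000 nM, which is a limit and not a number, and it differs from compound 2 in more than one place, so the effect of its ethyl ester at this position also stays unresolved.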